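Cyclopropyl in place of 2-chloroethyl on a carbonyl carbon

The source may hold more compounds than are shown below. What is called first, only, known or untested is meant among the compounds shown, and "the series" means these compounds.

In a functional assay on HCT-116 cells (Homo sapiens) for inhibition, read by MTT assay, with a stated time of 48 h (on this read-out lower numbers stand for stronger inhibition and higher numbers for weaker inhibition), compound 1 (`COCC(=O)N(Cc1ccc(OC)c(O)c1)c1cc(OC)c(OC)c(OC)c1`) gives 230 nM, compound 2 (`CCC/C=C/C(=O)N(Cc1ccc(OC)c(O)c1)c1cc(OC)c(OC)c(OC)c1`) gives 95 nM and compound 3 (`COc1ccc(CN(C(=O)CCCl)c2cc(OC)c(OC)c(OC)c2)cc1O`) gives 150 nM. Compound 3 therefore stands within the scatter of both others, as a 1.5-fold lower number from compound 1 to compound 3 (0.19 log units; within the scatter) and a 1.6-fold higher number from compound 2 to compound 3 (0.20 log units; within the scatter) show. Compound 4 (`COc1ccc(CN(C(=O)C2CC2)c2cc(OC)c(OC)c(OC)c2)cc1O`) differs from it by cyclopropyl in place of 2-chloroethyl on a carbonyl carbon. For the measured compounds named here, the steps that bear on this change alter the same group on the carbonyl carbon, and the largest, a 2.4-fold lower number from compound 1 to compound 2 (0.38 log units; beyond the scatter), is modest. None of them brings in a ring, so they guide the expectation only loosely. The expected step in this assay is a 1.2-fold lower number from compound 3 to compound 4 (0.06 log units; within the scatter), which is none beyond the scatter. Compound 4 is estimated at 130 nM, with an expected range from 50 nM to 340 nM.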

Compound 4, half-maximal inhibitory concentration: 49 nM
Compound 4: middle estimate off by 2.7-fold (0.42 log units), on the high side; measured number below the stated range.
By their numbers in this assay, from the lowest: compounds 4, 2, 3 and 1 (each within the scatter of the next, the first and the last beyond it).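

In this assay, only compound 4 carries a ring on the carbonyl carbon, and cyclopropyl gives a 3.1-fold lower number from compound 3 to compound 4 (0.49 log units; beyond the scatter) and a 4.7-fold lower number from compound 1 to compound 4 (0.67 log units; beyond the scatter) against the two open chains there. Against pent-1-en-1-yl the ring stays within the scatter, with a 1.9-fold lower number from compound 2 to compound 4 (0.29 log units; within the scatter) as the printed step, so this ring and that chain are not separated at this position. Nothing measured here accounts for these steps. The compounds shown leave open whether a cyclobutyl or phenyl group on the same carbonyl carbon would keep this level of inhibition, and whether cyclopropyl would do so in any other cell line.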